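The source may hold more compounds than are shown below. What is called first, only, known or untested is meant among the compounds shown, and "the series" means these compounds.

In an ADME assay (liver) for metabolic stability, with Liver microsome (Rattus norvegicus) as the target, using microsomes (a lower number here means slower removal, a higher number faster removal of the compound), compound 2 `CN(C(=O)c1ccc2ncsc2c1)c1ccc(OCc2ccc3ccccc3c2)cc1` gives 48.3 mL/min/kg and compound 1 `CN(C(=O)c1cc(-c2ccccn2)[nH]n1)c1ccc(OCB2C=Cc3ccccc3N2)cc1` gives 25 mL/min/kg. These two values lie within the usual scatter of repeated measurements, so this assay does not separate compound 2 from compound 1.

Compound 3 `CN(C(=O)c1cc(-c2ccccn2)[nH]n1)c1ccc(OCc2ccc3ccccc3c2)cc1` has not been measured yet. It differs from compound 2 in one place: on a carbonyl carbon, 5-(pyridin-2-yl)-1H-pyrazol-3-yl stands in place of 1,3-benzothiazol-6-yl (5-(pyridin-2-yl)-1H-pyrazol-3-yl in place of 1,3-benzothiazol-6-yl on a carbonyl carbon). For the measured compounds named here, no two measured compounds differ in just one place, so no measured step shows what this exchange does to clearance. Going by the values given here, the only hint comes from compound 1, which also carries the entering group and gives 25 mL/min/kg, a value that cannot be told apart from that of compound 2. A modest expectation therefore makes sense, leaning slightly towards slower removal. The estimated change is a 1.3-fold lower number from compound 2 to compound 3 (0.13 log units; within the scatter), an expected small fall that stays within the scatter. For compound 3 the expected clearance is 36 mL/min/kg, with an estimated range of 19 mL/min/kg to 68 mL/min/kg.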

Compound 3, clearance: 30 mL/min/kg
Beside the measured number, compound 3's estimate is 1.2-fold (0.08 log units) above it, within the range that was stated.
By their numbers in this assay, from the lowest: compounds 1, 3 and 2 (each within the scatter of the next).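

With compound 3 measured, the exchange on the carbonyl carbon whose other neighbour is the amide-type nitrogen can finally be read directly: putting 5-(pyridin-2-yl)-1H-pyrazol-3-yl in place of 1,3-benzothiazol-6-yl gives a 1.6-fold lower number from compound 2 to compound 3 (0.21 log units; within the scatter) in this assay and so does not separate the two compounds, even though the entering group carries a hydrogen-bond donor that the leaving group lacks. Compound 3 also gives a second reading at another place, the saturated chain carbon bound to an oxygen on an aromatic ring, where a two-ring group of carbon only in place of the boron-containing group gives a 1.2-fold higher number from compound 1 to compound 3 (0.08 log units; within the scatter) and again leaves the pair unresolved in this assay. Nothing measured here offers an explanation for either result. On these data alone, what remains open is whether any group on that carbonyl carbon, such as a plain phenyl ring or a chain ending in a carboxylic acid, would move clearance beyond the scatter. The same question stands at the chain carbon bound to the oxygen, where a single phenyl ring or a chain ending in an amine could be compared with the two-ring groups.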